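A Methyl Group on the Unsubstituted Phenyl of Compound 1

The compounds below may be only part of what the source reports. "The series", "measured", "known", "first", "only" and "open" are said of these compounds alone.

Compound 1 `CC(C)(C)N(NC(=O)c1ccccc1)C(=O)c1ccccc1Cl` is the unsubstituted parent of this small set. Among the measured compounds shown here, in an assay on cells for agonist activity at ecdysone receptor (Bombyx mori), read by a luciferase reporter, with a stated time of 24 h (on this read-out lower numbers stand for an effect already at smaller amounts and higher numbers for an effect only at larger amounts of compound), compound 1 gives 75.9 nM, the second highest of the three numbers measured so far. Compound 2 `CC(C)(C)N(NC(=O)c1cccc(Br)c1)C(=O)c1ccccc1Cl` gives 191 nM in this assay, and compound 3 `CC(C)(C)N(NC(=O)c1ccc(I)cc1)C(=O)c1ccccc1Cl` gives 7.59 nM. The step of a 2.5-fold higher number from compound 1 to compound 2 (0.40 log units; beyond the scatter) is modest, whereas a 10-fold lower number from compound 1 to compound 3 (1.00 log units; beyond the scatter) is a clear gain, and a 25-fold lower number from compound 2 to compound 3 (1.40 log units; beyond the scatter) sets the two halogenated compounds far apart.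

Compound 4 `Cc1ccc(C(=O)NN(C(=O)c2ccccc2Cl)C(C)(C)C)cc1` has not yet been measured. It differs from compound 1 by methyl in place of hydrogen on an aromatic carbon, so that phenyl becomes 4-methylphenyl. For the measured compounds named here, the measured step that bears most directly on it is the one from compound 1 to compound 3, because a 10-fold lower number from compound 1 to compound 3 (1.00 log units; beyond the scatter) also describes a group entering on an aromatic carbon of that ring, while the bromo step to compound 2 went the other way. Methyl is a smaller group than iodo, so a gain is expected, but a smaller one: the step is estimated as a 3.5-fold lower number from compound 1 to compound 4 (0.54 log units; beyond the scatter). Compound 4 is therefore expected to give 22 nM in this assay, within a range of 7 nM to 65 nM.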

Compound 4, half-maximal effective concentration: 18.6 nM
Estimate against measurement, compound 4: 1.2-fold (0.07 log units) above; the measured number falls inside the stated range.
By their numbers in this assay, from the lowest: compound 3; then compound 4; then compound 1; then compound 2.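

In this assay, a 4.1-fold lower number from compound 1 to compound 4 (0.61 log units; beyond the scatter) shows that the gain at this position, para to a large group, does not belong to iodo alone: methyl, a group of one carbon with no halogen, also lowers the number. Among the compounds shown here, the two groups are still not equal there, with a 2.5-fold higher number from compound 3 to compound 4 (0.39 log units; beyond the scatter), and 4-methylphenyl stands well apart from the 3-bromophenyl of compound 2, the one compound that goes against the gain, with a 10-fold lower number from compound 2 to compound 4 (1.01 log units; beyond the scatter). No measurement shown gives a reason for these differences.

On these data alone, it remains open whether a longer chain, an amine or a carboxylic acid at this position would lower the number as well. Compound 2 and compound 3 differ in both the halogen and its place, and the effects of these two changes cannot be separated.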